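The source may hold more compounds than are shown below. What is called first, only, known or untested is meant among the compounds shown, and "the series" means these compounds.

In a functional assay (aorta) with Rattus norvegicus as the target (a lower number here means that less compound is needed, a higher number that more compound is needed for the effect), compound 3 (`COc1ccc(-c2nc(C(=O)N(C)C)sc2-c2ccc(OC)cc2)cc1`) gives 3 uM. Compound 1 (`COc1ccc(-c2nc(CN(C)C)sc2-c2ccc(OC)cc2)cc1`) gives 8.4 uM, and compound 2 (`COc1ccc(-c2nc(CNC(=O)NC(C)C)sc2-c2ccc(OC)cc2)cc1`) gives 5.7 uM. Only one gap among these three clears the scatter: a 2.8-fold lower number from compound 1 to compound 3 (0.45 log units; beyond the scatter). The other two, a 1.5-fold lower number from compound 1 to compound 2 (0.17 log units; within the scatter) and a 1.9-fold lower number from compound 2 to compound 3 (0.28 log units; within the scatter), stay within it.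

The next structure, compound 4 (`COc1ccc(-c2nc(/C=C/C(=O)O)sc2-c2ccc(OC)cc2)cc1`), carries 2-carboxyethenyl in place of dimethylcarbamoyl on an aromatic carbon. The steps bearing on this change are a 2.8-fold lower number from compound 1 to compound 3 (0.45 log units; beyond the scatter) and a 1.9-fold lower number from compound 2 to compound 3 (0.28 log units; within the scatter), as both replace a group at this same place. Both are small, the first modest and the second within the scatter. Going by the values given here, no measured compound carries 2-carboxyethenyl, so the data do not fix the direction. A small move toward higher numbers in this assay is expected, with nothing beyond the scatter. The expected change is a 1.7-fold higher number from compound 3 to compound 4 (0.22 log units; within the scatter). For compound 4 the estimated value is 5 uM, with an expected range of 1.8 uM to 15 uM.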

Compound 4, concentration for half-maximal effect: 55 uM
Compound 4: middle estimate off by 11-fold (1.04 log units), on the low side, outside the stated range (above it).
By their numbers in this assay, from the lowest: compounds 3, 2 and 1 (each within the scatter of the next, the first and the last beyond it); then compound 4.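

Going by these compounds alone, at the aromatic carbon next to the ring nitrogen and next to the ring sulfur, 2-carboxyethenyl is the first group to move the number far from the others: in this assay there is an 18-fold higher number from compound 3 to compound 4 (1.26 log units; beyond the scatter), a 9.6-fold higher number from compound 2 to compound 4 (0.98 log units; beyond the scatter) and a 6.5-fold higher number from compound 1 to compound 4 (0.82 log units; beyond the scatter), so this position is not indifferent to the group it carries. Dimethylcarbamoyl and 2-carboxyethenyl both have 5 heavy atoms and no net charge, so these counts do not separate them, while the entering group adds 1 hydrogen-bond donor and a second double bond outside aromatic rings. No measurement here gives a reason for the rise.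

The compounds shown do not separate the carboxylic acid from the ethenyl link. A methyl ester or dimethylamide on the same ethenyl chain, or a carboxylic acid directly on the ring carbon, would bear on that question.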